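Swapping 2-chlorophenyl for 4-bromophenyl in compound 2

The source may hold more compounds than are shown below. What is called first, only, known or untested is meant among the compounds shown, and "the series" means these compounds.

- Compound 1 `CCCSc1nc(N/N=C(\C)c2ccccc2O)c2nnn(Cc3ccc(Cl)cc3)c2n1`: 11200 nM
- Compound 2 `CCCSc1nc(N/N=C/c2ccccc2Cl)c2nnn(Cc3ccccc3)c2n1`: 6180 nM
- Compound 3 `CCCSc1nc(N/N=C/c2cc(OC)c(OC)c(OC)c2)c2nnn(Cc3ccccc3)c2n1`: 4060 nM

All three values come from a functional assay on ECa-109 cells (Homo sapiens) for antiproliferative activity, read by MTT assay, with a stated time of 72 h; a lower number here means a stronger inhibitor, a higher number a weaker inhibitor. Compound 2 stands within the usual scatter of repeated measurements from both compound 1 and compound 3, so the numbers cannot separate it from either one.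

Compound 4 `CCCSc1nc(N/N=C/c2ccc(Br)cc2)c2nnn(Cc3ccccc3)c2n1` has not yet been measured. It differs from compound 2 in one place, with 4-bromophenyl in place of 2-chlorophenyl on a carbon with a double bond to nitrogen.

Among the measured compounds shown here, no two measured compounds differ in just one place, so no measured step shows what such a change does. The expectation rests only on compound 2 at 6180 nM and compound 3 at 4060 nM, two values within the scatter of each other. No change beyond the scatter is therefore expected in this assay. The expected result is a small shift, an estimated 1.2-fold lower number from compound 2 to compound 4 (0.09 log units; within the scatter). For compound 4 the estimated value is 5000 nM, with an expected range from 2000 nM to 12000 nM.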

Compound 4, half-maximal inhibitory concentration: > 64000 nM
Compound 4: no number, only a limit; the forecaster's own chance of this, stated with the estimate: 5%; middle value at least 12-fold (1.10 log units) from the limit.
By their numbers in this assay, from the lowest: compounds 3, 2 and 1 (each within the scatter of the next, the first and the last beyond it). At a limit, above all of these: compound 4.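

In this assay compound 4 gives > 64000 nM, which is a limit of the assay and not a measured number. Even so, this single swap on the carbon with a double bond to nitrogen gives an at least 10-fold higher number from compound 2 to compound 4 (1.01 log units; beyond the scatter), the first step in this set that changes one place only, and it shows that this position is not indifferent to the group it carries, even though 2-chlorophenyl and 4-bromophenyl have the same count of heavy atoms. The true size of the step stays unknown, and only the assay's limit bounds it: the limit of > 64000 nM in this assay, at which 1 of the 4 values shown sits.

As far as these compounds go, whether 4-chlorophenyl or 2-bromophenyl at this place would behave like compound 2 or like compound 4 stays open, and those two groups would separate the choice of halogen from where it sits on the ring. How a 4-aminophenyl group would behave there is open too.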